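The source may report more compounds than this note shows. Statements on the series, on what has been measured and on what is new or still open speak of the compounds shown alone.

Series notes. Within the data shown here, compound 1 `CC1CCCCN1C(=S)SCc1ccc(C(=O)Nc2ccccc2N)cc1` is the stronger of the two compounds measured so far in a functional assay on A-375 cells (Homo sapiens) for antiproliferative activity, read by CCK-8 assay, with a stated time of 72 h, tested at 2 uM; a lower number here means a weaker effect, a higher number a stronger effect of the compound at the concentration tested: compound 1 gives 42.5%. Compound 2 `Nc1ccccc1NC(=O)c1ccc(CSC(=S)N2CCN(c3ccccc3F)CC2)cc1` in this assay gives 18.7%, a number well below that of compound 1 and beyond the scatter; no one-place difference between compound 1 and compound 2 has been worked out, so only the two values themselves can be set side by side.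

The next compound, compound 3 `Nc1ccccc1NC(=O)c1ccc(CSC(=S)N2CCCC2)cc1`, keeps the shared core of compound 1 and alters one place: pyrrolidin-1-yl in place of 2-methylpiperidin-1-yl on a thiocarbonyl carbon. Among the measured compounds shown here, no measured step of this kind exists in the set, so the size of the effect cannot be read off. For the measured compounds named here, compound 2 shows that a different amine on the thiocarbonyl carbon can lower the read-out far below compound 1, but no example shows whether a five-membered ring in this place goes up or down. A modest downward step a number 7.5 percentage points lower from compound 1 to compound 3 (within the scatter) is expected, possibly none beyond the scatter. Compound 3 is therefore estimated at 35%, with a range from 15% to 55%.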

Compound 3, a percentage reported as inhibition, at one concentration (the size of the read-out at that concentration, not a potency): 30.2%
Compound 3: middle estimate off by 4.8 percentage points, on the high side; measured number inside the range.
By their numbers in this assay, from the lowest: compound 2; then compound 3; then compound 1.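

In this assay, the step at this position on a thiocarbonyl carbon can now be read directly: pyrrolidin-1-yl in place of 2-methylpiperidin-1-yl gives a number 12.3 percentage points lower from compound 1 to compound 3 (beyond the scatter), a modest step. This shows that the read-out responds to a change between two non-aromatic rings that each hold one hetero atom and carry no hydrogen-bond donors or acceptors, with no net charge on either group, so such a change alone is enough to move it. The change replaces a six-membered ring of 7 heavy atoms with a five-membered ring of 5 heavy atoms, and no measurement bears on why the read-out falls with this change.

The compounds shown leave open whether the step follows the ring size or the loss of the methyl group, since both change together between compound 1 and compound 3, and plain piperidin-1-yl would separate the two. They also leave open how the read-out responds to a second ring hetero atom, as in morpholin-4-yl, or to an open-chain diethylamino group at this position.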